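Replacing a Para Ethyl with Iodo on an Anilino Ring

This account rests on a few compounds, and the source may have more. Where it says the series, first, only, none or still open, it means among the compounds named here.

Measured so far:
- compound 1, `COc1ccccc1NC1=CC(=O)c2c(nc3n2[C@H]2OC[C@@H](O)[C@H]2OC3)C1=O`: 7460 nM
- compound 2, `CCc1ccc(NC2=CC(=O)c3nc4n(c3C2=O)[C@H]2OC[C@@H](O)[C@H]2OC4)cc1`: 3990 nM

Two compounds share a tricyclic core and differ only in the substituted aniline attached to it. In a functional assay on HeLa cells (Homo sapiens) for inhibition, read by sulforhodamine B assay (a lower number here means a stronger inhibitor, a higher number a weaker inhibitor), compound 1 gives 7460 nM, and in the same assay compound 2 gives 3990 nM. The gap between these two values lies within the usual scatter of repeated measurements, so neither compound can be called the stronger inhibitor on this evidence; compound 2 simply has the lower of the two numbers.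

Compound 3, `O=C1C=C(Nc2ccc(I)cc2)C(=O)c2c1nc1n2[C@H]2OC[C@@H](O)[C@H]2OC1`, has not yet been measured. It differs from compound 2 in one place: iodo in place of ethyl on an aromatic carbon. Within the data shown here, no measured pair here shows the effect of swapping one small para group for another, so there is no direct precedent. With only one heavy atom entering where two leave, and no change in donors, acceptors or charge, a modest shift is expected from compound 2 to compound 3, of a 1.3-fold lower number from compound 2 to compound 3 (0.12 log units; within the scatter), and not clearly beyond the scatter. Compound 3 is therefore expected to give about 3000 nM, within a range of 1000 nM to 9000 nM.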

Compound 3, half-maximal inhibitory concentration: 4070 nM
For compound 3 the middle estimate is 1.4-fold (0.13 log units) below the measured one; the measured number falls inside the stated range.
By their numbers in this assay, from the lowest: compounds 2, 3 and 1 (each within the scatter of the next).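

In this assay, placing iodo where compound 2 carries ethyl gives a 1.0-fold higher number from compound 2 to compound 3 (0.01 log units; within the scatter) on the anilino ring, so the two numbers cannot be told apart. Among these compounds, this pair offers the first direct comparison of two groups at this position, and a single iodine atom and a two-carbon ethyl group read alike here, even though they are different kinds of substituent. That shows only that this one exchange leaves no measurable mark on this read-out, not that the position is indifferent to whatever is placed there, and no measurement shown explains why the two groups read alike.

Ethyl and iodo both carry no hydrogen-bond donors or acceptors and no net charge, so the compounds shown leave open how this position would respond to a group that differs on those counts, such as a hydroxyl group or a carboxylic acid. Also open, on these data alone, is whether a longer chain such as butyl, or a smaller halogen such as fluoro, would stay within the same narrow band of values or move clearly away from it.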